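The source may report more compounds than this note shows. Statements on the series, on what has been measured and on what is new or still open speak of the compounds shown alone.

Going by the values given here, only two compounds have so far been tested in a functional assay on HeLa cells (Homo sapiens) for inhibition, read by MTT assay, with a stated time of 72 h (a higher number here means a weaker inhibitor, a lower number a stronger inhibitor), and both give high numbers. Compound 1 `C=C1CC[C@H]2[C@](C)(CO)CCC[C@]2(C)[C@H]1C[C@@]12O[C@@H]1[C@@H](O)C(CO)=CC2=O` gives 35900 nM, and compound 2 `C=C1CC[C@H]2[C@](C)(COC(C)=O)CCC[C@]2(C)[C@H]1C[C@]12O[C@H]1[C@H](O)C(CO)=CC2=O` gives 19200 nM. These two values lie within the scatter of each other, so compound 2 cannot be separated from compound 1 on these data. Compound 3 `C=C1CC[C@H]2[C@](C)(COC(C)=O)CCC[C@]2(C)[C@H]1C[C@@]12O[C@@H]1[C@@H](O)C(CO)=CC2=O` is the next to be tested, and it changes only the drawn configuration of compound 2: the two compounds have the same atoms and bonds and differ only in configuration as drawn: 3 of 7 stereo elements differ; a stereocentre at a saturated ring carbon is drawn S in compound 2 and R in compound 3; a stereocentre at a saturated ring carbon is drawn S in compound 2 and R in compound 3; a stereocentre at a saturated ring carbon is drawn R in compound 2 and S in compound 3. Among the compounds with values here, no measured step shows what such a change does in this assay, so the expectation rests on the narrow spread of the two values alone. The estimated change, a 1.1-fold higher number from compound 2 to compound 3 (0.06 log units; within the scatter), is expected to stay within the scatter, with no clear direction, although the range is kept wide. For compound 3 the expected value is 22000 nM, within an estimated range of 9000 nM to 50000 nM.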

Compound 3, half-maximal inhibitory concentration: 19600 nM
Beside the measured number, compound 3's estimate is 1.1-fold (0.05 log units) above it; low and high end bracket the measured number.
By their numbers in this assay, from the lowest: compounds 2, 3 and 1 (each within the scatter of the next).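

In this assay, the drawn configuration now has a measured step of its own, a 1.0-fold higher number from compound 2 to compound 3 (0.01 log units; within the scatter), so the three stereocentres that differ leave the read-out within the scatter. The second step, a 1.8-fold lower number from compound 1 to compound 3 (0.26 log units; within the scatter), also stays within the scatter, so acetyl in place of hydrogen on an oxygen on a saturated carbon cannot be told apart from the free hydroxyl in this assay. The first of these comparisons isolates a single kind of difference: the fact that compounds 2 and 3 differ only in the configuration as drawn

The compounds shown leave open whether a different group on that oxygen, such as a longer acyl chain, a carboxylic acid or an amine, would give a step beyond the scatter. They also leave open whether the shared core can reach much lower numbers in this assay.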